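A few compounds are considered here, and "the series" means these few. Any claim that something is new, unique, unknown or untested is made for them only; others in the source may bear on it.

The measured compounds:

Compound 1 `O=C(Nc1ccc(Cl)c(-c2nnc3c(Cl)cccn23)c1)c1cccnc1`: in a functional assay on AN3-CA cells (Homo sapiens) for antiproliferative activity, read by MTT assay, with a stated time of 72 h (on this read-out higher numbers stand for weaker inhibition and lower numbers for stronger inhibition), compound 1 gives > 100000 nM, which is a limit of the assay and not a number.
Compound 2 `O=C(Nc1ccc(Cl)c(-c2nnc3c(Cl)cccn23)c1)c1ccc(Cl)cc1`: in this assay compound 2 gives > 100000 nM, again a limit.
Compound 3 `CS(=O)(=O)c1ccc(C(=O)Nc2ccc(Cl)c(-c3nnc4c(Cl)cccn34)c2)cc1`: in this assay compound 3 gives > 100000 nM, also a limit.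

Compound 3 therefore stands at the limit of this assay, together with the other two values shown (the limit of > 100000 nM in this assay, at which 3 of the 3 values shown sit). The move to compound 4 `O=C(Nc1ccc(Cl)c(-c2nnc3c(Cl)cccn23)c1)c1ccc(Cl)cc1Cl` makes one change: 2,4-dichlorophenyl in place of 4-(methylsulfonyl)phenyl on a carbonyl carbon. The steps that touch this position are a step that the two limits leave unreadable from compound 2 to compound 3 and a step that the two limits leave unreadable from compound 1 to compound 3, and the remaining step that the two limits leave unreadable from compound 1 to compound 2 is no more readable. No measured step gives a direction or a size, so nothing beyond the scatter can be expected from the shown numbers. Compound 4 is accordingly expected to give 100000 nM, with a range from 30000 nM to 300000 nM, most likely reported as a limit again. The expected step is a number no higher from compound 3 to compound 4 (the limit leaves the size open).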

Compound 4, half-maximal inhibitory concentration: 84800 nM
Compound 4: the middle estimate sits 1.2-fold (0.07 log units) above what was measured; the range from low to high includes it.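

In this assay only compound 4 of the four compounds gives a number and not a limit of the assay, with 2,4-dichlorophenyl on the carbonyl carbon: the limit of > 100000 nM in this assay, at which 3 of the 4 values shown sit. Against the earlier compounds this gives an at least 1.1-fold lower number from compound 3 to compound 4 (0.07 log units; that floor lies within the scatter) as well as an at least 1.1-fold lower number from compound 2 to compound 4 (0.07 log units; that floor lies within the scatter) for chloro in place of hydrogen on an aromatic carbon, and an at least 1.1-fold lower number from compound 1 to compound 4 (0.07 log units; that floor lies within the scatter) at the same place. Among the compounds shown here, these floors are all that can be read, so the position gives a first value but no change beyond the scatter.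

The steps among compound 1, compound 2 and compound 3 still cannot be read, and every group shown on the carbonyl carbon is an aromatic ring. As far as these compounds go, what an amine, a carboxylic acid or a longer alkyl chain would do at this place stays open.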